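The source may hold more compounds than are shown below. What is called first, only, known or untested is meant among the compounds shown, and "the series" means these compounds.

Three compounds share one core and differ at two places. Compound 1 `Cn1c(C2CC2)nc2ccc(-n3ccc(OCc4ccc(F)cc4)cc3=O)cc21` carries a cyclopropyl group on an aromatic carbon of the core and a 4-fluorophenyl group on a saturated chain carbon bound to an oxygen on an aromatic ring. In an assay on CHO cells for displacement of a labelled ligand from melanin-concentrating hormone receptor 1 (Homo sapiens), read by scintillation counting, with a stated time of 1 h (on this read-out lower numbers stand for stronger inhibition and higher numbers for weaker inhibition), compound 1 gives 40 nM. Compound 2 `Cn1c(CC(C)(C)C)nc2ccc(-n3ccc(OCc4ccc(F)cc4)cc3=O)cc21` has a neopentyl group in place of the cyclopropyl group. In this assay compound 2 reaches only a limit of the assay, > 1000 nM (the limit of > 1000 nM in this assay, at which 1 of the 3 values shown sits). That change is costly: an at least 25-fold higher number from compound 1 to compound 2 (1.39 log units; beyond the scatter). Compound 3 `Cn1c(C2CC2)nc2ccc(-n3ccc(OCc4cccc(Cl)c4)cc3=O)cc21` keeps the cyclopropyl group and carries a 3-chlorophenyl group instead of the 4-fluorophenyl group; in this assay compound 3 gives 100 nM, the higher of the two numbers shown, and the step is a 2.5-fold higher number from compound 1 to compound 3 (0.40 log units; beyond the scatter).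

Compound 4 `Cn1c(C2CC2)nc2ccc(-n3ccc(OCc4ccc(Cl)s4)cc3=O)cc21` differs from compound 3 at that same place: 5-chlorothiophen-2-yl in place of 3-chlorophenyl on a saturated chain carbon bound to an oxygen on an aromatic ring. Going by the values given here, no measured step swaps a six-membered aromatic ring for a five-membered one, so the only guide is the single step at this place, a 2.5-fold higher number from compound 1 to compound 3 (0.40 log units; beyond the scatter), which was modest. A change at this place is therefore expected to stay small, likely within the scatter or a little beyond. The expected step is a 1.2-fold higher number from compound 3 to compound 4 (0.08 log units; within the scatter). For compound 4 the estimate in this assay is 120 nM, with a range from 40 nM to 400 nM.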

Compound 4, half-maximal inhibitory concentration: 19 nM
For compound 4 the middle estimate is 6.3-fold (0.80 log units) above the measured one, and the stated range ends above it.
By their numbers in this assay, from the lowest: compound 4; then compound 1; then compound 3. At a limit, above all of these: compound 2.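

Going by these compounds alone, the only earlier change at this place, from compound 1 to compound 3, raised the number, which could suggest that changes here simply cost binding, but compound 4 shows that the group can also move the number down. In this assay, replacing a six-membered aromatic ring of carbon only with a five-membered aromatic ring with one hetero atom gives a 5.3-fold lower number from compound 3 to compound 4 (0.72 log units; beyond the scatter), a larger step than the earlier one at this place and in the opposite direction. The new group also improves on the 4-fluorophenyl group, with a 2.1-fold lower number from compound 1 to compound 4 (0.32 log units; beyond the scatter), so the gain does not depend on 3-chlorophenyl being a poor reference; nothing in the data shown explains why the number falls.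

Each group shown at this place carries a halogen, and compounds 3 and 4 differ in both the ring and where the chlorine sits, so the ring's share of the step cannot be separated from the chlorine's: plain thiophen-2-yl would address this directly. As far as these compounds go, it also remains open how this place responds to a pyridine ring, which has a ring nitrogen, or to an amine on the aromatic ring.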